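The compounds below may be only part of what the source reports. "The series", "measured", "known", "first", "only" and "open" are said of these compounds alone.

Measured so far in a functional assay on SK-BR-3 cells (Homo sapiens) for antiproliferative activity, read by MTT assay, with a stated time of 72 h; on this read-out lower numbers stand for stronger inhibition and higher numbers for weaker inhibition:
- compound 1 `Cc1cc(NCCN(C)C)nc2ccc(NC(=O)c3ccc(Cl)c(Cl)c3)cc12` — 6670 nM
- compound 2 `Cc1cc(N(C)C)nc2ccc(NC(=O)c3ccc(Cl)c(Cl)c3)cc12` — a limit of the assay, > 50000 nM
- compound 3 `Cc1cc(N2CCN(C(C)C)CC2)nc2ccc(NC(=O)c3ccc(Cl)c(Cl)c3)cc12` — 6680 nM

Compound 3 stands at the highest of the two numbers shown, but compound 1 sits within the scatter of it: a 1.0-fold higher number from compound 1 to compound 3 (0.00 log units; within the scatter). Compound 2 gives only a limit (the limit of > 50000 nM in this assay, at which 1 of the 3 values shown sits), so the step of an at least 7.4-fold lower number from compound 2 to compound 3 (0.87 log units; beyond the scatter) is at least modest and in the direction of stronger inhibition.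

Compound 4 `Cc1cc(N2CCCCC2)nc2ccc(NC(=O)c3ccc(Cl)c(Cl)c3)cc12` is not yet measured. It differs from compound 3 in one place: piperidin-1-yl in place of 4-isopropylpiperazin-1-yl on an aromatic carbon. The step that bears on this is the exchange between compound 2 and compound 3, where a single-nitrogen dimethylamino group stands against the two-nitrogen 4-isopropylpiperazin-1-yl ring; the step from compound 1 to compound 3 shows that the two-nitrogen groups are interchangeable within the scatter. Piperidin-1-yl, with its one hetero atom, is nearer to the case of compound 2 than to that of compound 3.

A step of weaker inhibition is therefore expected: a 3.7-fold higher number from compound 3 to compound 4 (0.57 log units; beyond the scatter), beyond the scatter but probably short of the limit. Compound 4 is estimated in this assay at 25000 nM, in the range 8000 nM to 60000 nM.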

Compound 4, half-maximal inhibitory concentration: 42500 nM
Estimate against measurement, compound 4: 1.7-fold (0.23 log units) below; the measured number falls inside the stated range.
By their numbers in this assay, from the lowest: compounds 1 and 3 (each within the scatter of the next); then compound 4. At a limit, above all of these: compound 2.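

In this assay, the group on the aromatic carbon next to the ring nitrogen sets the level of inhibition even when a six-membered non-aromatic ring stays in place: a 6.4-fold higher number from compound 3 to compound 4 (0.80 log units; beyond the scatter) is a modest step towards weaker inhibition, so that ring alone does not hold the level of compound 3. The open-chain comparison gives the same picture, a 6.4-fold higher number from compound 1 to compound 4 (0.80 log units; beyond the scatter), again a modest step, and so among the compounds shown, the two groups with 2 nitrogens give the lower numbers, with no compound going against this. Compound 2 stands at a limit: the limit of > 50000 nM in this assay, at which 1 of the 4 values shown sits. The step of an at least 1.1-fold lower number from compound 2 to compound 4 (0.07 log units; that floor lies within the scatter) cannot be read as a size, as its floor lies within the scatter.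

The compounds shown do not separate the second ring nitrogen from its isopropyl group, a question that piperazin-1-yl, 4-methylpiperazin-1-yl and morpholin-4-yl would each bear on. Going by these compounds, how far the side chain of compound 1 can change also remains open, for instance with a longer chain such as (3-(dimethylamino)propyl)amino or with a primary amine at its end.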